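The compounds below may be only part of what the source reports. "The series", "measured", "known", "first", "only" and "open" are said of these compounds alone.

Measured compounds in the series:

compound 1 `NC(=S)N/N=C/c1ccc2ccccc2n1` — 32700 nM
compound 2 `N#Cc1ccc(NC(=S)N/N=C/c2ccc3ccccc3n2)cc1` — 23700 nM
compound 3 `S=C(N/N=C/c1ccc2ccccc2n1)Nc1ccccc1Br` — a limit of the assay, > 100000 nM

All three share one core, and the compounds differ only in the group on the amide-type nitrogen. In a functional assay on SGC-7901 cells (Homo sapiens) for antiproliferative activity, read by sulforhodamine B assay, with a stated time of 72 h (on this read-out lower numbers stand for stronger inhibition and higher numbers for weaker inhibition), compound 1 gives 32700 nM; of the two numbers shown it is the top one, yet the step of a 1.4-fold lower number from compound 1 to compound 2 (0.14 log units; within the scatter) leaves compound 2 within the scatter of compound 1. For compound 3 the assay reports only a limit, (the limit of > 100000 nM in this assay, at which 1 of the 3 values shown sits). The steps of an at least 3.0-fold higher number from compound 1 to compound 3 (0.48 log units; beyond the scatter) and an at least 4.2-fold higher number from compound 2 to compound 3 (0.62 log units; beyond the scatter) are therefore the only ones beyond the scatter, and both concern the amide-type nitrogen.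

Compound 4 `CN(C)C(=S)N/N=C/c1ccc2ccccc2n1` changes a different place: dimethylamino in place of amino on a thiocarbonyl carbon. Among the measured compounds shown here, no measured step touches the amino on the thiocarbonyl carbon, so none of the three steps bears directly on this change. The series gives no ground for a shift in either direction, so the step in this assay is expected to stay within the scatter.

For compound 4 the estimate in this assay is 33000 nM, with a range from 9000 nM to 100000 nM. The step that this estimate means, a 1.0-fold higher number from compound 1 to compound 4 (0.00 log units; within the scatter), is the expected one.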

Compound 4, half-maximal inhibitory concentration: 30 nM
Beside the measured number, compound 4's estimate is 1100-fold (3.04 log units) above it, and the stated range ends above it.
By their numbers in this assay, from the lowest: compound 4; then compounds 2 and 1 (each within the scatter of the next). At a limit, above all of these: compound 3.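

Among the compounds shown here, the thiocarbonyl carbon, which no earlier step touched, proves to be a highly responsive place: in this assay, dimethylamino in place of amino gives a 1100-fold lower number from compound 1 to compound 4 (3.04 log units; beyond the scatter), whereas the change on the amide-type nitrogen in a 1.4-fold lower number from compound 1 to compound 2 (0.14 log units; within the scatter) stays within the scatter. This single step combines the loss of the hydrogen-bond donor counted on amino with the gain of the added carbon atoms, so the result cannot assign the shift to either one. Nothing shown here bears on the reason for so large a step.

Still open, on these data alone, is whether methylamino, diethylamino or a cyclic amine such as morpholine on the thiocarbonyl carbon would keep a number close to that of compound 4, which would help separate the loss of the donor from the size of the group. Also open, as far as these compounds go, is whether dimethylamino keeps its effect when 4-cyanophenyl or 2-bromophenyl takes the place of hydrogen on the amide-type nitrogen.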